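Furan-2-yl for thiophen-2-yl on a flat series

The source may hold more compounds than are shown below. What is called first, only, known or untested is meant among the compounds shown, and "the series" means these compounds.

compound 1 `O=C1ON=C(c2cccs2)/C1=C/c1ccc(O)cc1` gives 4200 nM
compound 2 `O=C1ON=C(c2cccs2)/C1=C/c1ccccc1` gives 4400 nM
compound 3 `O=C1ON=C(c2cccs2)/C1=C/c1cccs1` gives 3700 nM

In a functional assay on the whole organism for inhibition, with Rattus norvegicus as the target (a lower number here means a stronger inhibitor, a higher number a weaker inhibitor), compound 3 holds 3700 nM and stands within the scatter of both other compounds. The next step leads to compound 4 `O=C1ON=C(c2cccs2)/C1=C/c1ccco1` and is furan-2-yl in place of thiophen-2-yl on a double-bonded chain carbon bound to a double-bonded ring carbon.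

Among the measured compounds shown here, two measured steps bear on it. The closer one is an exchange at that same place, thiophen-2-yl in place of phenyl, which gave a 1.2-fold lower number from compound 2 to compound 3 (0.08 log units; within the scatter) and stayed within the scatter. The other, hydrogen in place of hydroxy on an aromatic carbon, gave a 1.0-fold higher number from compound 1 to compound 2 (0.02 log units; within the scatter) and also stayed within the scatter. No step beyond the scatter is therefore expected in this assay and no direction can be named. The expected step is a 1.1-fold higher number from compound 3 to compound 4 (0.03 log units; within the scatter) and this remains an estimate. Compound 4 is estimated at 4000 nM (expected range 2200 nM to 7500 nM).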

Compound 4, half-maximal inhibitory concentration: 5800 nM
Estimate against measurement, compound 4: 1.5-fold (0.16 log units) below; measured number inside the range.
By their numbers in this assay, from the lowest: compounds 3, 1, 2 and 4 (each within the scatter of the next).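

In this assay, furan-2-yl now joins phenyl and thiophen-2-yl on a double-bonded chain carbon bound to a double-bonded ring carbon, and the series remains flat at this place: the exchange gives a 1.6-fold higher number from compound 3 to compound 4 (0.20 log units; within the scatter) and, against phenyl, gives a 1.3-fold higher number from compound 2 to compound 4 (0.12 log units; within the scatter) as well. Replacing the sulfur of the five-membered aromatic ring with oxygen, with the heavy-atom count unchanged, therefore stays within the scatter, as does the exchange of either five-membered ring for phenyl in the pairs shown. There is no evidence here on why this place responds so little.

Every group shown at this place is an uncharged aromatic ring, so it remains open whether an amine, a carboxylic acid or a longer chain there would move the number beyond the scatter. The thiophen-2-yl on the shared core is the same in all four compounds, and its contribution cannot be read.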